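The source may hold more compounds than are shown below. What is called first, only, known or untested is meant among the compounds shown, and "the series" means these compounds.

Measured compounds:
- compound 1 `O=C(N/N=C/c1ccc(O)cc1)c1cccnc1Nc1cccc(C(F)(F)F)c1`: 70.5%
- compound 2 `COc1ccc(/C=N/NC(=O)c2cccnc2Nc2cccc(C(F)(F)F)c2)cc1`: 59.4%

Both compounds were tested in a functional assay on the whole organism (strain Wistar) for inhibition, with Rattus norvegicus as the target, read by paw edema, with a stated time of 1 h, at a dose of 10 mg/kg by the intraperitoneal route; on this read-out higher numbers stand for more inhibition at the one dose given (going by the name of the read-out) and lower numbers for less inhibition. Compound 1 gives 70.5%, and compound 2 gives 59.4%. Going by the values given here, of the two numbers so far, compound 2 stands lowest, its nearest neighbour being compound 1, and the only measured step, a number 11.1 percentage points lower from compound 1 to compound 2 (beyond the scatter), is a modest drop that lies beyond the usual scatter.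

The next compound, compound 3 `O=C(N/N=C/c1cccnc1)c1cccnc1Nc1cccc(C(F)(F)F)c1`, has not yet been measured. It differs from compound 2 in one place: pyridin-3-yl in place of 4-methoxyphenyl on a carbon with a double bond to nitrogen. Among the compounds with values here, the single measured step swapped a hydrogen for a methyl on the oxygen of this same ring, while the change here exchanges the whole ring, so that step only loosely bears on it, and nothing measured shows what a ring with one nitrogen does at this position. With only that modest drop to go by, a step within the scatter or a small shift in either direction seems most plausible.

Compound 3 is therefore expected to come out near 60%, within a range from 42% to 76%, which means an expected step of a number 0.6 percentage points higher from compound 2 to compound 3 (within the scatter).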

Compound 3, a percentage reported as inhibition, in the whole organism at one dose (the size of the read-out at that dose, not a potency): 76.1%
Beside the measured number, compound 3's estimate is 16.1 percentage points below it, and the stated range ends below it.
By their numbers in this assay, from the lowest: compound 2; then compounds 1 and 3 (each within the scatter of the next).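

In this assay, exchanging 4-methoxyphenyl for pyridin-3-yl on the carbon with a double bond to nitrogen gives a number 16.7 percentage points higher from compound 2 to compound 3 (beyond the scatter), so this position responds to a change of the whole ring and not only to a small change on the ring's oxygen. Exchanging 4-hydroxyphenyl for pyridin-3-yl gives a number 5.6 percentage points higher from compound 1 to compound 3 (within the scatter), which shows that among these compounds, a ring without the hydroxy group of compound 1 can still give a number within the scatter of that compound. Nothing available explains how either ring exchange alters the read-out.

The step to compound 3 removes the methoxy group and brings a ring nitrogen in a single exchange, so the compounds shown leave open how much each of these two changes contributes, a question that a plain phenyl ring at this position could help to settle. They also leave open how the pyridin-3-yl ring would behave with a further group attached, such as an amine or a carboxylic acid.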